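A hydroxy group added to compound 1

The source may report more compounds than this note shows. Statements on the series, on what has been measured and on what is new or still open speak of the compounds shown alone.

In a functional assay on NCI/ADR-RES cells (Homo sapiens) for inhibition, read by sulforhodamine B assay, with a stated time of 48 h (a higher number here means a weaker inhibitor of growth, a lower number a stronger inhibitor of growth), compound 1 (`CC1(/C=C/c2ccccc2)C=CC(=O)O1`) gives 414000 nM. Compound 2 (`CC1(/C=C/c2ccccc2O)C=CC(=O)O1`) gives 78000 nM, and compound 3 (`CC1(/C=C/c2cccc(O)c2)C=CC(=O)O1`) gives 647000 nM. Compound 1 therefore stands within the scatter of compound 3, while compound 2 has a clearly lower number than compound 1.

Compound 4 (`CC1(/C=C/c2ccc(O)cc2)C=CC(=O)O1`) has not yet been measured. It differs from compound 1 by hydroxy in place of hydrogen on an aromatic carbon, para to a group of 9 heavy atoms.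

Within the data shown here, two measured steps bear on this change, as each also puts hydroxy in place of hydrogen on an aromatic carbon of compound 1. One is a 5.3-fold lower number from compound 1 to compound 2 (0.72 log units; beyond the scatter), and the other is a 1.6-fold higher number from compound 1 to compound 3 (0.19 log units; within the scatter). These two steps do not agree, so they set no single size for the new step, and neither compound carries the hydroxy at the carbon used in compound 4. The expectation in this assay is therefore a small step towards a lower number, with no change beyond the scatter.

The expected change is a 1.2-fold lower number from compound 1 to compound 4 (0.07 log units; within the scatter). For compound 4 the estimated value is 350000 nM, with an expected range from 120000 nM to 800000 nM.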

Compound 4, concentration for total growth inhibition: 111000 nM
The estimate for compound 4 lay 3.2-fold (0.50 log units) above the measured number; the measured number lies below the stated range.
By their numbers in this assay, from the lowest: compounds 2 and 4 (each within the scatter of the next); then compounds 1 and 3 (each within the scatter of the next).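

In this assay, hydroxy in place of hydrogen on an aromatic carbon, para to a group of 9 heavy atoms, gives a step beyond the scatter (a 3.7-fold lower number from compound 1 to compound 4 (0.57 log units; beyond the scatter)), so this is a place on the ring of compound 1 where the change registers. The step runs in the same direction as the earlier one (a 5.3-fold lower number from compound 1 to compound 2 (0.72 log units; beyond the scatter)), which makes two hydroxy steps beyond the scatter towards a lower number, while the third step goes against them and stays within the scatter (a 1.6-fold higher number from compound 1 to compound 3 (0.19 log units; within the scatter)). Compound 2 gives 78000 nM and compound 4 gives 111000 nM, values within the scatter of each other, so this assay does not separate these two hydroxy placements.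

No evidence is available on what lies behind these steps. As far as these compounds go, it also remains open whether hydroxy itself matters at this carbon or whether a methoxy group, an amine or a carboxylic acid in the same place would give a step of similar size.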